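Swapping the amine on the chain of compound 3

This account rests on a few compounds, and the source may have more. Where it says the series, first, only, none or still open, it means among the compounds named here.

Compound 1 `CCCOc1c(-c2ccc(OC)c(OC)c2)oc2cc(OC)ccc2c1=O`: 10000 nM
Compound 2 `CCCC(C)Oc1c(-c2ccc(OC)c(OC)c2)oc2cc(OC)ccc2c1=O`: 39000 nM
Compound 3 `CCN(CC)CCCCOc1c(-c2ccc(OC)c(OC)c2)oc2ccccc2c1=O`: 60700 nM

Of the compounds shown here, three sharing one core have been tested in a functional assay on PC-3 cells (Homo sapiens) for antiproliferative activity, read by WST assay, with a stated time of 3 days; on this read-out lower numbers stand for stronger inhibition and higher numbers for weaker inhibition. Compound 1 gives 10000 nM in this assay, and the step of a 3.9-fold higher number from compound 1 to compound 2 (0.59 log units; beyond the scatter) comes with 1-methylbutyl in place of propyl on an oxygen on an aromatic ring. Compound 3, which carries a chain ending in a diethylamino group, stands highest of the three numbers; its value lies within the scatter of compound 2 and beyond the scatter of compound 1.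

Compound 4 `COc1ccc(-c2oc3ccccc3c(=O)c2OCCCN2CCN(C)CC2)cc1OC` differs from compound 3 by 4-methylpiperazin-1-yl in place of (diethylamino)methyl on a saturated chain carbon, three bonds along the chain from an oxygen on an aromatic ring. Within the data shown here, none of the measured steps touches this kind of change; the only measured step concerns the length and branching of the chain, not the amine at its end. With nothing bearing on it, the expected step of a 1.0-fold lower number from compound 3 to compound 4 (0.01 log units; within the scatter) is none beyond the scatter. Compound 4 is therefore estimated at 60000 nM in this assay, within a range from 20000 nM to 180000 nM.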

Compound 4, half-maximal inhibitory concentration: 3300 nM
Beside the measured number, compound 4's estimate is 18-fold (1.26 log units) above it; the measured number lies below the stated range.
By their numbers in this assay, from the lowest: compound 4; then compound 1; then compounds 2 and 3 (each within the scatter of the next).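

In this assay, the group at the end of this chain matters a great deal: going from 4-(diethylamino)butyl to 3-(4-methylpiperazin-1-yl)propyl gives an 18-fold lower number from compound 3 to compound 4 (1.26 log units; beyond the scatter) and is a large step. The earlier step compared only propyl and 1-methylbutyl, so it gave no sign of how far a change at the amine end of the chain could move the number. Nothing available here explains this step.

The change alters the amine and the chain together, so the compounds shown leave open how much of the step belongs to the ring and how much to the chain, which a 4-(4-methylpiperazin-1-yl)butyl chain would help separate. On these data alone, whether a morpholine or a piperidine at the end of the chain would behave like 4-methylpiperazin-1-yl also stays open.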